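The compounds below may be only part of what the source reports. "The series", "measured", "known", "first", "only" and "open" are said of these compounds alone.

The study is followed here through an assay on isolated protein for inhibition of phosphoenolpyruvate carboxykinase, cytosolic [GTP] (Homo sapiens); a higher number here means a weaker inhibitor, a lower number a stronger inhibitor. Among the compounds with values here, compound 1 `O=c1c2[nH]c(Cc3ccc(NS(=O)(=O)c4cccc5cccnc45)cc3)nc2n(CC2CC2)c(=O)n1Cc1ccccc1F` gives 450 nM in this assay, the lower of the two numbers measured so far. Compound 2 `CCCCn1c(=O)n(Cc2ccccc2F)c(=O)c2[nH]c(Cc3ccc(NC(C)=O)cc3)nc21` belongs to the same core but carries a butyl chain and an acetamide in place of the sulfonamide, and in this assay compound 2 gives 2110 nM; the gap between the two measured values lies beyond the usual scatter, though the two structures differ in more than one place, so no single step can be read from them.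

The unmeasured compound 3 `Cc1nn(C)cc1S(=O)(=O)Nc1ccc(Cc2nc3c([nH]2)c(=O)n(Cc2ccccc2F)c(=O)n3CC2CC2)cc1` keeps everything of compound 1 except the group on the sulfonyl sulfur, where the change is 1,3-dimethyl-1H-pyrazol-4-yl in place of quinolin-8-yl on a sulfonyl sulfur. Within the data shown here, no step between measured compounds shows what such an exchange does in this assay. On the strength of compound 1 and its value of 450 nM alone, the expectation is a modest weakening, with a step from compound 1 to compound 3 estimated at a 2.2-fold higher number from compound 1 to compound 3 (0.35 log units; beyond the scatter), possibly within the scatter. Compound 3 is therefore expected to give about 1000 nM, with a range from 300 nM to 3500 nM.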

Compound 3, half-maximal inhibitory concentration: 240 nM
Compound 3: middle estimate off by 4.2-fold (0.62 log units), on the high side; measured number below the stated range.
By their numbers in this assay, from the lowest: compounds 3 and 1 (each within the scatter of the next); then compound 2.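

Within the data shown here, the exchange on the sulfonyl sulfur is the first single change that can be read in this assay, and it amounts to a 1.9-fold lower number from compound 1 to compound 3 (0.27 log units; within the scatter). Quinolin-8-yl, with its two six-membered aromatic rings and 10 heavy atoms, can thus be replaced by 1,3-dimethyl-1H-pyrazol-4-yl, with one five-membered aromatic ring and 7 heavy atoms, and the two compounds stay within the scatter of each other, so this position accepts both groups in this assay. No measurement shown here offers an explanation for this result.

As far as these compounds go, this single pair is all that speaks for the position, so it remains open how a plain phenyl ring, a methyl group or a morpholine on the sulfonyl sulfur would fare. From the compounds shown here alone, compound 2 differs from compound 1 and compound 3 in more than one place, so its steps cannot be read, and the separate contributions of its butyl chain and its acetamide remain unknown.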